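The compounds below may be only part of what the source reports. "The series", "measured", "known", "first", "only" and "open" are said of these compounds alone.

In a physicochemical assay for lipophilicity, at pH 7.4 (on this read-out higher numbers stand for higher lipophilicity and lower numbers for lower lipophilicity), compound 1 `Cc1cc(C(N)=O)nn1Cc1cc(Cl)ccc1OCc1ccccc1` gives 3.7. Compound 2 `Cc1cc(C(=O)Nc2ccccc2)nn1Cc1cc(Cl)ccc1OCc1ccccc1` carries phenyl in place of hydrogen on the amide-type nitrogen, and its reading of > 3.7 is a limit, not a number. The step itself is a number no lower from compound 1 to compound 2 (the limit leaves the size open), so its direction is partly known but its size is not. Compound 3 `Cc1cc(C(N)=O)nn1Cc1cc(Cl)ccc1OCC(C)C`, with isopropyl in place of phenyl on the saturated chain carbon bound to the oxygen, gives 3.1, the lower of the two true numbers in this small set. That change is a number 0.60 log units lower from compound 1 to compound 3 (beyond the scatter).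

Compound 4 `Cc1cc(C(=O)NN2CCOCC2)nn1Cc1cc(Cl)ccc1OCC(C)C` differs from compound 3 at the amide-type nitrogen: morpholin-4-yl in place of hydrogen on an amide-type nitrogen. Morpholin-4-yl takes the place of hydrogen there. Going by these compounds, the closest guide is a number no lower from compound 1 to compound 2 (the limit leaves the size open), a step at this same kind of nitrogen, although a different group enters and the size stays open. The other measured step, a number 0.60 log units lower from compound 1 to compound 3 (beyond the scatter), lies elsewhere in the molecule and serves only as a yardstick for a modest change. A modest rise in this assay is what is expected here, namely a number 0.40 log units higher from compound 3 to compound 4 (beyond the scatter). Compound 4 is estimated at 3.5, with an expected range from 3 to 4.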

Compound 4, distribution coefficient: 3.1
Compound 4: middle estimate off by 0.40 log units, on the high side; the measured number falls inside the stated range.
By their numbers in this assay, from the lowest: compounds 3 and 4 (each within the scatter of the next); then compound 1.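

In this assay, morpholin-4-yl on the amide-type nitrogen gives no change at the digits printed from compound 3 to compound 4 (within the scatter), so this nitrogen can carry a group of 6 heavy atoms, with one six-membered non-aromatic ring, and the reading stays within the scatter. Within the data shown here, the only earlier step at this nitrogen, with phenyl entering on compound 1, gave a limit and no size: the limit of > 3.7 in this assay, at which 1 of the 4 values shown sits. Among these compounds, this is therefore the first step at this position whose size can be read, and it shows that a substantial group on the amide nitrogen need not move the reading in this assay.

It remains one step on one background, the compound with isopropyl on the saturated chain, so it is not known whether morpholin-4-yl would read the same way on compound 1, which has phenyl there. Also open, going by these compounds, is how the reading would respond on this nitrogen to a piperidin-1-yl ring, which has carbon where morpholin-4-yl has its ring oxygen, or to a methyl group or a longer carbon chain.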